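Adding a Second Chloro to the Benzyl Ether Arm

The compounds below may be only part of what the source reports. "The series", "measured", "known", "first", "only" and "open" are said of these compounds alone.

Compound 1 `O=[N+]([O-])c1cc(C(F)(F)F)cc([N+](=O)[O-])c1Oc1ccccc1/C=N/OCc1ccccc1Cl` and compound 2 `O=[N+]([O-])c1cc(C(F)(F)F)cc([N+](=O)[O-])c1Oc1ccccc1/C=N/OCc1ccc(Cl)cc1Cl` share one core and differ in a single place: chloro in place of hydrogen on an aromatic carbon. In a functional assay on MCF7 cells (Homo sapiens) for antiproliferative activity, read by MTT assay, with a stated time of 48 h (a lower number here means a stronger inhibitor, a higher number a weaker inhibitor), compound 1 gives 1100 nM. In the same this assay compound 2 gives 940 nM. Between the two there is a 1.2-fold lower number from compound 1 to compound 2 (0.07 log units; within the scatter), so the added chloro left the number essentially where it was.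

Compound 3 `O=[N+]([O-])c1cc(C(F)(F)F)cc([N+](=O)[O-])c1Oc1ccc(Cl)cc1/C=N\OCc1ccccc1Cl` is built on a second core; the difference between the core of compound 1 and the core of compound 3 is not broken down here. In this assay compound 3 gives 3950 nM, the highest of the three numbers, and its gaps to compound 1 and to compound 2 both lie beyond the scatter.

Compound 4 `O=[N+]([O-])c1cc(C(F)(F)F)cc([N+](=O)[O-])c1Oc1ccc(Cl)cc1/C=N\OCc1ccc(Cl)cc1Cl` has not yet been measured. It differs from compound 3 by the same change already seen in the first pair: chloro in place of hydrogen on an aromatic carbon, placed identically around the ring. Going by the values given here, the only guide to its size is that earlier pair. Because the earlier step was a 1.2-fold lower number from compound 1 to compound 2 (0.07 log units; within the scatter), a step of about the same small size is expected here, namely a 1.2-fold lower number from compound 3 to compound 4 (0.07 log units; within the scatter). On that basis compound 4 is estimated at 3400 nM in this assay. Among the compounds with values here, the expected range for compound 4 runs from 1700 nM to 7000 nM, reflecting that only one prior instance supports the guess.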

Compound 4, half-maximal inhibitory concentration: 1140 nM
Estimate against measurement, compound 4: 3.0-fold (0.47 log units) above; measured number below the stated range.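

In this assay, going from 2-chlorobenzyl to 2,4-dichlorobenzyl gives a 3.5-fold lower number from compound 3 to compound 4 (0.54 log units; beyond the scatter), so on this core the added chloro moves the number by more than the usual scatter, whereas on the core of compound 1 it did not. Going by these compounds alone, the change therefore did not carry over at one fixed size, and a step read on one core was a poor guide to the step on the other: the same change on two cores in this assay, a 1.2-fold lower number (0.07 log units; within the scatter) from compound 1 to compound 2 and a 3.5-fold lower number (0.54 log units; beyond the scatter) from compound 3 to compound 4, 3.0-fold (0.47 log units) apart, beyond the scatter of two such steps This rests on only two pairs, so it shows that the core can matter but gives no general rule, and the data do not tell which feature of the core of compound 3 sets its step apart or why the size differs.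

The compounds shown leave open whether a bromo, a methoxy or an amine, placed where the new chloro sits on the benzyl ring, would also give steps of different size on the two cores. They also leave open how large the same chloro step would be on any third core, which would help show whether the larger or the smaller step is the more typical.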